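A few compounds are considered here, and "the series" means these few. Any claim that something is new, unique, unknown or untested is made for them only; others in the source may bear on it.

Of the compounds shown here, three from this study have been measured in a functional assay on A549 cells (Homo sapiens) for inhibition, read by sulforhodamine B assay; a lower number here means a stronger inhibitor of growth, a higher number a weaker inhibitor of growth. Compound 1, `CC1(C)CCC[C@]2(C)[C@@H](/C=C/C3=CCOC3=O)C(C=O)=CC(=O)[C@@H]12`, gives 18500 nM in this assay. Compound 2, `C=C1CC[C@H]2C(C)(C)CCC[C@]2(C)[C@H]1C/C=C1/CC(O)OC1=O`, gives 8000 nM in this assay. Compound 3, `CC(C)(O)C1CC[C@@]2(C)CCC[C@@](C)(O)[C@@H]2C1`, gives 14500 nM in this assay. Compound 1 stands at the highest of the three numbers. Its gap to compound 3 lies within the usual scatter of repeated measurements, so the two cannot be told apart, whereas its gap to compound 2 lies beyond that scatter, so compound 2 is the stronger inhibitor of growth of that pair.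

Compound 4, `CC1=CC(=O)[C@H]2C(C)(C)CCC[C@]2(C)[C@H]1/C=C/C1=CCOC1=O`, has not yet been measured. It differs from compound 1 in a single place: methyl in place of formyl on a double-bonded ring carbon. Within the data shown here, no two measured compounds differ in just one place, so no measured step shows what this kind of swap does in this assay. The expectation therefore rests only on compound 1 itself, whose value of 18500 nM sets the starting point, and on the small size of the change.

For compound 4 the expected value in this assay is 24000 nM, with a range from 8000 nM to 70000 nM. That estimate corresponds to an expected step of a 1.3-fold higher number from compound 1 to compound 4 (0.11 log units; within the scatter), small and not clearly beyond the scatter, with no firm direction.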

Compound 4, concentration for 50% growth inhibition: 21700 nM
The estimate for compound 4 lay 1.1-fold (0.04 log units) above the measured number; the range from low to high includes it.
By their numbers in this assay, from the lowest: compounds 2, 3, 1 and 4 (each within the scatter of the next, the first and the last beyond it).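

In this assay, putting methyl in place of formyl on this double-bonded ring carbon gives a 1.2-fold higher number from compound 1 to compound 4 (0.07 log units; within the scatter), so compound 1 and compound 4 cannot be told apart. Among these compounds, this is the first measured step at this position, and it shows that, in this pair, the formyl group with its double bond and its hydrogen-bond acceptor can give way to a smaller methyl group, which has no hydrogen-bond acceptor, without a difference beyond the scatter. Nothing measured on these compounds explains this result.

It remains open whether a different group on the same ring carbon, such as an amine, a carboxylic acid or a longer chain, would shift the number beyond the scatter, for only formyl and methyl are shown there. This step also comes from a single pair in this assay, and it cannot say whether the same swap would give a similar result on a compound with a different group on the neighbouring ring atom, such as the side chain of compound 2.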